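The source may report more compounds than this note shows. Statements on the series, on what has been measured and on what is new or still open speak of the compounds shown alone.

Measured compounds:
- compound 1, `Cc1coc(C(=O)CCCCCCc2ccccc2)n1`: 520 nM
- compound 2, `O=C(CCCCCCc1ccccc1)c1nc(-c2cccnc2)co1`: 18 nM

In an assay on isolated protein for inhibition of Fatty-acid amide hydrolase 1 (Rattus norvegicus) (on this read-out lower numbers stand for stronger inhibition and higher numbers for weaker inhibition), compound 2 stands lowest of the two numbers; its nearest neighbour is compound 1, which gives 520 nM. Going by the values given here, the only step in hand, a 29-fold lower number from compound 1 to compound 2 (1.46 log units; beyond the scatter), is large and runs beyond the scatter.

Compound 3, `CNC(=O)c1coc(C(=O)CCCCCCc2ccccc2)n1`, carries methylcarbamoyl in place of pyridin-3-yl on an aromatic carbon. The ring that drove the step from compound 1 to compound 2 is thus removed and replaced by a smaller, ring-free group; the expectation is that much of that gain is lost, giving a rise in this assay on the order of an 8.3-fold higher number from compound 2 to compound 3 (0.92 log units; beyond the scatter). Compound 3 is therefore estimated at 150 nM, within 40 nM to 600 nM.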

Compound 3, inhibition constant: 1.8 nM
Estimate against measurement, compound 3: 83-fold (1.92 log units) above; measured number outside the range, below it.
By their numbers in this assay, from the lowest: compound 3; then compound 2; then compound 1.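

In this assay, the position next to the ring nitrogen does not need an aromatic ring to reach a low number: methylcarbamoyl, which has no ring, gives a 10-fold lower number from compound 2 to compound 3 (1.00 log units; beyond the scatter). Against methyl at the same position, the change gives a 290-fold lower number from compound 1 to compound 3 (2.46 log units; beyond the scatter), so the amide outdoes the pyridin-3-yl group here. Nothing at hand explains this difference between the groups. Open, going by these compounds, is whether the amide hydrogen matters, which a dimethylamide or a methyl ester would test. Also open, on these data alone, is how a primary carboxamide or a carboxylic acid would read at this position.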